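Acetylation of the sulfonamide in the diaryl-pyrazole series

The source may report more compounds than this note shows. Statements on the series, on what has been measured and on what is new or still open speak of the compounds shown alone.

Compound 1 `Oc1ccc(O)c(-c2cc(-c3ccccc3)nn2-c2ccccc2)c1` gives 67300 nM in a functional assay on cells (Cancer cell lines, Homo sapiens) for cytotoxicity, read by sulforhodamine B assay, with a stated time of 48 h; on this read-out higher numbers stand for weaker inhibition of growth and lower numbers for stronger inhibition of growth. Compound 2 `NS(=O)(=O)c1ccc(-n2nc(-c3ccccc3)cc2-c2cc(O)ccc2O)cc1` gives 99300 nM, the highest of the two numbers; the step of a 1.5-fold higher number from compound 1 to compound 2 (0.17 log units; within the scatter) stays within the scatter. Compound 3 `CC(=O)NS(=O)(=O)c1ccc(-n2nc(-c3ccccc3)cc2-c2cc(O)ccc2O)cc1` differs from compound 2 by acetyl in place of hydrogen on a sulfonamide nitrogen. For the measured compounds named here, no measured step touches the sulfonamide nitrogen, and the only step in hand, a 1.5-fold higher number from compound 1 to compound 2 (0.17 log units; within the scatter), is itself within the scatter, so for compound 3 the expected step of a 1.1-fold higher number from compound 2 to compound 3 (0.04 log units; within the scatter) is none beyond the scatter. Compound 3 is therefore estimated at 110000 nM, with a range from 45000 nM to 270000 nM.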

Compound 3, concentration for total growth inhibition: 100000 nM
Compound 3: the middle estimate sits 1.1-fold (0.04 log units) above what was measured; the measured number falls inside the stated range.
By their numbers in this assay, from the lowest: compounds 1, 2 and 3 (each within the scatter of the next).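

In this assay, the step at the sulfonamide nitrogen is now read directly: acetyl in place of hydrogen gives a 1.0-fold higher number from compound 2 to compound 3 (0.00 log units; within the scatter). Acetylsulfamoyl in place of hydrogen on an aromatic carbon gives a 1.5-fold higher number from compound 1 to compound 3 (0.17 log units; within the scatter), so this larger group, like sulfamoyl, does not separate from hydrogen at that carbon. No available data explain this result.

Still open, as far as these compounds go, is whether a longer chain on the sulfonamide nitrogen, such as butanoyl, or a benzoyl there would give a step beyond the scatter. A carboxylic acid in place of the sulfamoyl also remains to be read.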